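Chlorophenylsulfonamide isomers in the indazole series

A few compounds are considered here, and "the series" means these few. Any claim that something is new, unique, unknown or untested is made for them only; others in the source may bear on it.

The series shares a sulfonamide-linked indazole core with a benzyl group bearing an acetamide-type side chain. Compound 1, `CC(=O)NCc1cccc(Cn2nc(NS(=O)(=O)c3ccc(Cl)s3)c3c(CO)cccc32)c1`, carries a hydroxymethyl on the core and a chlorothiophene sulfonyl group; in a functional assay on CHO cells for antagonist activity at C-C chemokine receptor type 4 (Homo sapiens), read by GTPgammaS binding (on this read-out higher numbers stand for weaker inhibition and lower numbers for stronger inhibition), compound 1 gives 6.31 nM. Compound 2, `COc1cc(F)cc2c1c(NS(=O)(=O)c1ccc(Cl)s1)nn2Cc1cccc(CNC(C)=O)c1`, keeps the chlorothiophene sulfonyl but has a methoxy and a fluorine on the core; in this assay compound 2 gives 39.8 nM. Compound 3, `COc1cccc2c1c(NS(=O)(=O)c1ccc(Cl)c(Cl)c1)nn2Cc1cccc(CNC(=O)C(C)(C)O)c1`, has a methoxy on the core, a dichlorophenyl sulfonyl group and a hydroxy-isobutyramide side chain; in this assay compound 3 gives 398 nM. Compound 3 thus stands at the highest number of the three, separated from both compound 2 and compound 1 by gaps that lie beyond the usual scatter.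

Compound 4, `COc1cccc2c1c(NS(=O)(=O)c1cccc(Cl)c1Cl)nn2Cc1cccc(CNC(=O)C(C)(C)O)c1`, differs from compound 3 only in how the two chlorines sit on the phenyl ring: 2,3-dichlorophenyl in place of 3,4-dichlorophenyl on a sulfonyl sulfur. Within the data shown here, no measured pair isolates such a rearrangement, so there is no basis for expecting a shift beyond the scatter in either direction. The step from compound 3 to compound 4 is therefore expected to be small, a 1.0-fold higher number from compound 3 to compound 4 (0.00 log units; within the scatter). Compound 4 is estimated at 400 nM, with a range of 130 nM to 1300 nM.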

Compound 4, half-maximal inhibitory concentration in the C-C chemokine receptor type 4 assay: 398 nM
Compound 4: middle estimate off by 1.0-fold (0.00 log units), on the high side; measured number inside the range.
By their numbers in the C-C chemokine receptor type 4 assay, from the lowest: compound 1; then compound 2; then compounds 3 and 4 (each within the scatter of the next).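

Among these compounds, in the C-C chemokine receptor type 4 assay, 2,3-dichlorophenyl in place of 3,4-dichlorophenyl on a sulfonyl sulfur gives no change at the digits printed from compound 3 to compound 4 (within the scatter), the first comparison in which only one place differs. Compounds 1 and 2 could not show this, and the pair establishes that, with this core and side chain, the receptor number does not register this rearrangement of the two chlorines. In a physicochemical assay for lipophilicity (on this read-out higher numbers stand for higher lipophilicity and lower numbers for lower lipophilicity), compound 3 gives 5.1 and compound 4 gives 4.7. In the physicochemical assay, the same change gives a number 0.40 log units lower from compound 3 to compound 4 (beyond the scatter), so at this position the lower lipophilicity of compound 4 comes without any shift in the receptor number: the measured distribution coefficient of compound 3, 5.1, and of compound 4, 4.7, a number 0.40 log units lower (beyond the scatter)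

Compounds 1 and 2 differ from compounds 3 and 4 in more than one place, so their lower numbers in the C-C chemokine receptor type 4 assay cannot be assigned to the sulfonyl group, the core substituents or the side chain separately. As far as these compounds go, whether this tolerance extends to a 2,4-dichlorophenyl or a phenyl bearing a single chlorine on the same sulfonyl sulfur remains open, as does whether it would hold with an acetamide in place of the hydroxy-isobutyramide side chain.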